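Propylcarbonyl on the Aromatic Nitrogen: What to Expect

The compounds below may be only part of what the source reports. "The series", "measured", "known", "first", "only" and "open" are said of these compounds alone.

Measured compounds:
- Compound 1, `COc1cc(/C=C/C(=O)c2cccc(NC(=O)c3ccco3)c2)ccc1O`, gives 61% in a functional assay on HUVEC cells (Homo sapiens) for inhibition, tested at 2.5 ug/mL; a higher number here means a stronger effect of the compound at the concentration tested, a lower number a weaker effect.
- Compound 2, `COc1cc(/C=C/C(=O)c2cccc(N)c2)ccc1O`, gives 20% in this assay.
- Compound 3, `COc1cc(/C=C/C(=O)c2cccc(NC(=O)c3cc(Cl)cc(Cl)c3)c2)ccc1O`, gives 15% in this assay.

All three share one core and differ only at a nitrogen on an aromatic ring. Compound 2 carries a plain hydrogen there and sits well below compound 1, while its value and that of compound 3 lie within the scatter of each other, so no order between those two can be claimed.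

Compound 4, `CCCC(=O)Nc1cccc(C(=O)/C=C/c2ccc(O)c(OC)c2)c1`, is not yet measured. Compared with compound 2 it differs as follows: propylcarbonyl in place of hydrogen on a nitrogen on an aromatic ring. The change is the same kind as the two steps already seen at that nitrogen. Going a number 41 percentage points lower from compound 1 to compound 2 (beyond the scatter) shows that removing a (furan-2-yl)carbonyl costs a large amount of inhibition; going a number 5 percentage points lower from compound 2 to compound 3 (within the scatter) shows that adding a (3,5-dichlorophenyl)carbonyl changes nothing beyond the scatter. An acyl group at this position can therefore help a great deal or not at all, and a propylcarbonyl matches neither case closely. A moderate rise is expected, with wide uncertainty: compound 4 is estimated at 32%, between 10% and 60%, a step of a number 12 percentage points higher from compound 2 to compound 4 (beyond the scatter).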

Compound 4, a percentage reported as inhibition, at one concentration (the size of the read-out at that concentration, not a potency): 40%
The estimate for compound 4 lay 8 percentage points below the measured number, and the stated range covers the measured number.
By their numbers in this assay, from the lowest: compounds 3 and 2 (each within the scatter of the next); then compound 4; then compound 1.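

A propylcarbonyl on this nitrogen gives a real gain in this assay, a number 20 percentage points higher from compound 2 to compound 4 (beyond the scatter), so an acyl group here can raise the number without carrying any ring. The group attached to the carbonyl carbon also matters: propyl in place of 3,5-dichlorophenyl gives a number 25 percentage points higher from compound 3 to compound 4 (beyond the scatter), whereas propyl in place of furan-2-yl gives a number 21 percentage points lower from compound 1 to compound 4 (beyond the scatter). The three acyl groups therefore give three clearly separated levels, with compound 1 still the highest of the four compounds, but no measurement is available to explain this order.

On these data alone, it remains open whether a shorter acetyl or a longer pentylcarbonyl would land above or below compound 4. A plain benzoyl group would show how the unsubstituted phenyl ring compares with both the furan-2-yl and 3,5-dichlorophenyl groups.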